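Anilinoquinazoline thioacetamide series: meta-substituent on the anilide ring

A few compounds are considered here, and "the series" means these few. Any claim that something is new, unique, unknown or untested is made for them only; others in the source may bear on it.

Measured compounds:
compound 1 `O=C(CSc1nc(Nc2ccccc2)c2ccccc2n1)Nc1cccc(F)c1` — 6790 nM
compound 2 `O=C(CSc1nc(Nc2ccccc2)c2ccccc2n1)Nc1cccc(Br)c1` — 10100 nM
compound 3 `O=C(CSc1nc(Nc2ccccc2)c2ccccc2n1)Nc1cccc([N+](=O)[O-])c1` — 17900 nM

All three share one core and differ only in the group on the anilide ring. In a functional assay on NCI-H1975 cells (Homo sapiens) for inhibition, read by MTT assay, with a stated time of 72 h (on this read-out lower numbers stand for stronger inhibition and higher numbers for weaker inhibition), compound 3 gives a number that stands apart from compound 1 by a 2.6-fold higher number from compound 1 to compound 3 (0.42 log units; beyond the scatter), while its gap to compound 2, a 1.8-fold higher number from compound 2 to compound 3 (0.25 log units; within the scatter), is within the scatter; the step of a 1.5-fold higher number from compound 1 to compound 2 (0.17 log units; within the scatter) is also within the scatter. Compound 4 `CCc1cccc(NC(=O)CSc2nc(Nc3ccccc3)c3ccccc3n2)c1` keeps the core and carries ethyl in place of nitro on an aromatic carbon. Going by the values given here, no measured step exchanges nitro for ethyl, so the only bearing comes from the fact that the two compounds without nitro, compound 1 and compound 2, give numbers at or below that of compound 3. A move back toward those numbers is therefore expected, modest in size and possibly within the scatter. For compound 4 the expectation in this assay is 9000 nM, with a range from 4000 nM to 20000 nM, which means a step of a 2.0-fold lower number from compound 3 to compound 4 (0.30 log units; within the scatter).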

Compound 4, half-maximal inhibitory concentration: 12000 nM
Estimate against measurement, compound 4: 1.3-fold (0.12 log units) below, and the stated range covers the measured number.
By their numbers in this assay, from the lowest: compounds 1, 2, 4 and 3 (each within the scatter of the next, the first and the last beyond it).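

In this assay, ethyl is the only alkyl group shown at this position, and the step from nitro is a 1.5-fold lower number from compound 3 to compound 4 (0.17 log units; within the scatter) while the step from bromo is a 1.2-fold higher number from compound 2 to compound 4 (0.07 log units; within the scatter) and the step from fluoro is a 1.8-fold higher number from compound 1 to compound 4 (0.25 log units; within the scatter) with all three within the scatter. Exchanging nitro for ethyl removes the hydrogen-bond acceptors counted on nitro without moving the number beyond the scatter, and the gap between the fluoro and nitro compounds remains the only one in the set that exceeds it. Nothing available explains these steps.

An amine, a carboxylic acid or a longer chain such as butyl could show whether this position tolerates more than the narrow span seen so far. Going by these compounds, whether changes elsewhere on the shared core matter more also remains open.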